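Replacing 2-Methyl-3-Nitrophenyl with Pentyl in a Weak Set

A few compounds are considered here, and "the series" means these few. Any claim that something is new, unique, unknown or untested is made for them only; others in the source may bear on it.

In a functional assay on MCF7 cells (Homo sapiens) for antiproliferative activity, read by MTT assay (on this read-out lower numbers stand for stronger inhibition and higher numbers for weaker inhibition), compound 1 (`CC1(C)CCc2cc(C(=O)/C=C/c3ccc(OCc4cn(-c5ccc(Cl)cc5)nn4)cc3)c(O)cc2O1`) is reported as "not active" (no number reported) with no number, and compound 3 (`CC1(C)CCc2cc(C(=O)/C=C/c3ccc(OCc4cn(Cc5ccc([N+](=O)[O-])cc5)nn4)cc3)c(O)cc2O1`) as "not active" (no number reported) with no number either. Compound 2 (`Cc1c(-n2cc(COc3ccc(/C=C/C(=O)c4ccc5c(c4O)CCC(C)(C)O5)cc3)nn2)cccc1[N+](=O)[O-]`) stands alone with 145000 nM as the only figure in the set. Compound 4 (`CCCCCn1cc(COc2ccc(/C=C/C(=O)c3ccc4c(c3O)CCC(C)(C)O4)cc2)nn1`) carries pentyl in place of 2-methyl-3-nitrophenyl on an aromatic nitrogen. Among the compounds with values here, no measured pair shows what such a change does, so no shift beyond the scatter is expected in this assay and no direction can be argued. The expected step (a 1.2-fold lower number from compound 2 to compound 4 (0.08 log units; within the scatter)) is therefore small. Compound 4 may also return no number, but it is estimated at 120000 nM with an expected range from 40000 nM to 350000 nM in this case.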

Compound 4, half-maximal inhibitory concentration: 191000 nM
Beside the measured number, compound 4's estimate is 1.6-fold (0.20 log units) below it; the measured number falls inside the stated range.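

Within the data shown here, on the aromatic nitrogen of the five-membered ring, pentyl in place of 2-methyl-3-nitrophenyl gives a 1.3-fold higher number from compound 2 to compound 4 (0.12 log units; within the scatter) in this assay, the first step that can be read at this position. An open chain with no ring can therefore stand here in place of a substituted aromatic ring with no change beyond the scatter. Nothing measured here bears on why this is so. Still open, on these data alone, is whether a longer chain, or a chain ending in an amine or a carboxylic acid, would shift the number beyond the scatter.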